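This account rests on a few compounds, and the source may have more. Where it says the series, first, only, none or still open, it means among the compounds named here.

Series notes, acyl and sulfonyl caps on the amine nitrogen of the shared core.

Compound 3 `Cc1cc(C)c(S(=O)(=O)N[C@@H](CNC(=O)CO[C@@H]2C[C@@H](CNc3ccccn3)N(C(=O)OCc3ccccc3)C2)C(=O)O)c(C)c1` gives 3.7 nM in an assay on a protein complex for inhibition of integrin alpha-5/beta-1 (Homo sapiens), read by ELISA; on this read-out lower numbers stand for stronger inhibition and higher numbers for weaker inhibition. Among the three numbers so far it stands second highest; its nearest neighbour is compound 1 `Cc1cc(C)c(C(=O)N[C@@H](CNC(=O)CO[C@@H]2C[C@@H](CNc3ccccn3)N(C(=O)OCc3ccccc3)C2)C(=O)O)c(C)c1`, which in this assay gives 3.5 nM, and its furthest is compound 2 `O=C(CO[C@@H]1C[C@@H](CNc2ccccn2)N(C(=O)OCc2ccccc2)C1)NC[C@H](NC(=O)c1ccccc1)C(=O)O`, which gives 155 nM. The step from compound 1 to compound 3 is a 1.1-fold higher number from compound 1 to compound 3 (0.02 log units; within the scatter), so exchanging the carbonyl for the sulfonyl under the same aryl group is not resolved here. The step of a 44-fold higher number from compound 1 to compound 2 (1.65 log units; beyond the scatter) and the step of a 42-fold lower number from compound 2 to compound 3 (1.62 log units; beyond the scatter) show that the loss of the three methyls on the aryl group is the change that matters in this set.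

Compound 4 `CC1(C(=O)N[C@@H](CNC(=O)CO[C@@H]2C[C@@H](CNc3ccccn3)N(C(=O)OCc3ccccc3)C2)C(=O)O)CCCCC1` carries the change ((1-methylcyclohexyl)carbonyl in place of (2,4,6-trimethylphenyl)sulfonyl on an amine nitrogen). Going by the values given here, the measured steps bear on it only partly: the cap returns to a carbonyl, which compound 1 shows to be as good as the sulfonyl, but the aromatic ring gives way to a saturated one, and no measured step covers that exchange. Some weakening beyond the scatter is therefore expected for compound 4, with an estimated step of a 4.1-fold higher number from compound 3 to compound 4 (0.61 log units; beyond the scatter) and an expected value of 15 nM, in the range 3 nM to 80 nM.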

Compound 4, half-maximal inhibitory concentration: 1.7 nM
Compound 4: the middle estimate sits 8.8-fold (0.95 log units) above what was measured; the measured number lies below the stated range.
By their numbers in this assay, from the lowest: compound 4; then compounds 1 and 3 (each within the scatter of the next); then compound 2.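

In this assay the cap on the amine nitrogen does not need an aromatic ring: the saturated (1-methylcyclohexyl)carbonyl gives a 2.1-fold lower number from compound 1 to compound 4 (0.31 log units; beyond the scatter) against the aryl carbonyl and a 2.2-fold lower number from compound 3 to compound 4 (0.34 log units; beyond the scatter) against the aryl sulfonyl, which leaves compound 4 with the lowest number of the four. The step of a 91-fold lower number from compound 2 to compound 4 (1.96 log units; beyond the scatter) places the benzoyl cap of compound 2 alone at the high end, so the low numbers in this set are not tied to one ring type, and the two ring types so far differ only modestly once the plain phenyl is left aside. Nothing at hand accounts for the saturated ring matching or bettering the aromatic caps.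

Open, on these data alone, is what the single methyl on the cyclohexane ring contributes, which a plain cyclohexylcarbonyl or a pivaloyl cap would test, and whether a (1-methylcyclohexyl)sulfonyl cap tracks the carbonyl as closely as the 2,4,6-trimethylphenyl pair does. Also open, as far as these compounds go, is whether the gain from this cap holds when the carboxylic acid gives way to an ester or the benzyl carbamate on the shared core gives way to a simple amide.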